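Removing the 4-carboxypiperidin-1-yl group from compound 1

The source may report more compounds than this note shows. Statements on the series, on what has been measured and on what is new or still open speak of the compounds shown alone.

Compound 1 `Cc1ccc(-c2nc3ccccc3s2)cc1NC(=O)c1cc([N+](=O)[O-])c(N2CCC(C(=O)O)CC2)cc1Cl` gives 17 10^-6 cm/s in this series
Compound 2 `COc1ccc(-c2nc3ccccc3s2)cc1NC(=O)c1cc([N+](=O)[O-])c(N2CCC(C(=O)O)CC2)cc1Cl` gives 5 10^-6 cm/s in this series

In an ADME assay for permeability, using PAMPA, at pH 7.4 (on this read-out lower numbers stand for lower permeability and higher numbers for higher permeability), compound 1 stands at 17 10^-6 cm/s and is the higher of the two measured compounds. The change from compound 1 to compound 3 `Cc1ccc(-c2nc3ccccc3s2)cc1NC(=O)c1cc([N+](=O)[O-])ccc1Cl` is hydrogen in place of 4-carboxypiperidin-1-yl on an aromatic carbon on an aromatic carbon, ortho to a nitro group. For the measured compounds named here, the only measured step of a 3.4-fold lower number from compound 1 to compound 2 (0.53 log units; beyond the scatter) is modest and beyond the scatter, but it concerns methoxy in place of methyl. It offers a scale and no direction. Going by the values given here, the expected change in this assay is a 2.4-fold higher number from compound 1 to compound 3 (0.37 log units; beyond the scatter) as a moderate rise, although no measured step covers this place. For compound 3 the estimate is 40 10^-6 cm/s with 10 10^-6 cm/s to 100 10^-6 cm/s as its range.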

Compound 3, apparent permeability: 41 10^-6 cm/s
Beside the measured number, compound 3's estimate is 1.0-fold (0.01 log units) below it, within the range that was stated.
By their numbers in this assay, from the lowest: compound 2; then compound 1; then compound 3.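

In this assay, taking away the whole 4-carboxypiperidin-1-yl group, ortho to a nitro group, gives a 2.4-fold higher number from compound 1 to compound 3 (0.38 log units; beyond the scatter), a modest step. For the compounds shown here, the earlier step concerned a different place, so this is the first direction seen at this position. No available evidence bears on what lies behind this rise. The compounds shown leave open whether the rise follows the carboxylic acid or the ring that carries it. A plain piperidin-1-yl group or a morpholine at this position would separate the two.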